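A few compounds are considered here, and "the series" means these few. Any claim that something is new, unique, unknown or untested is made for them only; others in the source may bear on it.

Compound 1, `CCOc1ccccc1Nc1nc(SCc2ccc(C(F)(F)F)cc2)nc2ccccc12`: in a functional assay on MDA-MB-231 cells (Homo sapiens) for cytotoxicity, read by MTT assay, with a stated time of 72 h (a higher number here means a weaker inhibitor, a lower number a stronger inhibitor), compound 1 gives > 50000 nM, which is a limit of the assay, (the limit of > 50000 nM in this assay, at which 1 of the 3 values shown sits), and not a number.
Compound 2, `Cc1ccccc1Nc1nc(SCc2ccc(C(F)(F)F)cc2)nc2ccccc12`: in this assay compound 2 gives 27100 nM.
Compound 3, `O=[N+]([O-])c1cccc(Nc2nc(SCc3ccc(C(F)(F)F)cc3)nc3ccccc23)c1`: in this assay compound 3 gives 31500 nM.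

Compound 3 and compound 2 stand close together: a 1.2-fold higher number from compound 2 to compound 3 (0.07 log units; within the scatter), so the two numbers cannot be told apart. Compound 1 gives only a limit, and an at least 1.5-fold lower number from compound 1 to compound 3 (0.20 log units; that floor lies within the scatter), as does an at least 1.8-fold lower number from compound 1 to compound 2 (0.26 log units; that floor lies within the scatter).

Compound 4, `FC(F)(F)c1ccc(CSc2nc(Nc3ccc(C(F)(F)F)cc3)c3ccccc3n2)cc1`, differs from compound 3 in one place: 4-(trifluoromethyl)phenyl in place of 3-nitrophenyl on a nitrogen on an aromatic ring. Two measured steps also swap the group on that nitrogen, from compound 1 to compound 3 and from compound 2 to compound 3, and neither reached beyond the scatter; the remaining step, an at least 1.8-fold lower number from compound 1 to compound 2 (0.26 log units; that floor lies within the scatter), is likewise a floor inside it. Among the compounds with values here, no measured step brings in a 4-(trifluoromethyl)phenyl on that nitrogen. The expected step in this assay from compound 3 to compound 4 is therefore none beyond the scatter, that is a 1.0-fold higher number from compound 3 to compound 4 (0.01 log units; within the scatter). Compound 4 is expected to give about 32000 nM, within a range from 12000 nM to 85000 nM.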

Compound 4, half-maximal inhibitory concentration: 5460 nM
The estimate for compound 4 lay 5.9-fold (0.77 log units) above the measured number, and the stated range ends above it.
By their numbers in this assay, from the lowest: compound 4; then compounds 2 and 3 (each within the scatter of the next). At a limit, above all of these: compound 1.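

The group on this nitrogen can move the number after all: in this assay, 4-(trifluoromethyl)phenyl gives a 5.8-fold lower number from compound 3 to compound 4 (0.76 log units; beyond the scatter) and also a 5.0-fold lower number from compound 2 to compound 4 (0.70 log units; beyond the scatter), whereas the earlier swaps at this nitrogen stayed within the scatter. Against compound 1 the step reads an at least 9.1-fold lower number from compound 1 to compound 4 (0.96 log units; beyond the scatter), but this is only a floor, as compound 1 gives a limit of the assay and not a number: the limit of > 50000 nM in this assay, at which 1 of the 4 values shown sits.

Compound 4 therefore separates from compounds 2 and 3, although each of these steps changes both the group on the phenyl ring and where it is written on that ring, so the compounds cannot show which of the two matters. Also open, from the compounds shown here alone, is how a phenyl ring carrying an amine or a carboxylic acid would read, and whether anything outside this nitrogen's group, which is the same in all four compounds, affects the number.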